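Series notes: 3-cyanophenyl to 4-carbamoylphenyl on the aryl amine

The source may hold more compounds than are shown below. What is called first, only, known or untested is meant among the compounds shown, and "the series" means these compounds.

Three measured compounds share one core and differ only in the aryl group on the ring nitrogen. Compound 1 `CCOc1ccc(Br)cc1-c1cc(Nc2ccc(B(O)O)cc2)nc(N)n1` gives 91 nM in an assay on Sf9 cells for inhibition of 1-acyl-sn-glycerol-3-phosphate acyltransferase beta (Homo sapiens); a lower number here means a stronger inhibitor, a higher number a weaker inhibitor. Compound 2 `CCOc1ccc(Br)cc1-c1cc(Nc2ccc(C#N)cc2)nc(N)n1` gives 17 nM in this assay, the change being a 5.4-fold lower number from compound 1 to compound 2 (0.73 log units; beyond the scatter). Compound 3 `CCOc1ccc(Br)cc1-c1cc(Nc2cccc(C#N)c2)nc(N)n1` gives 720 nM in this assay, the highest number of the three: a 42-fold higher number from compound 2 to compound 3 (1.63 log units; beyond the scatter), and a 7.9-fold higher number from compound 1 to compound 3 (0.90 log units; beyond the scatter).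

Compound 4 `CCOc1ccc(Br)cc1-c1cc(Nc2ccc(C(N)=O)cc2)nc(N)n1` is not yet measured. Its difference from compound 3 is 4-carbamoylphenyl in place of 3-cyanophenyl on a nitrogen on an aromatic ring. For the measured compounds named here, two steps bear on this. The large step of a 42-fold higher number from compound 2 to compound 3 (1.63 log units; beyond the scatter) shows that shifting the nitrile from 4-cyanophenyl to 3-cyanophenyl raised the number sharply, so returning to a 4-substituted aryl should lower it again. The modest step of a 5.4-fold lower number from compound 1 to compound 2 (0.73 log units; beyond the scatter) shows that, among 4-substituted aryls, the nature of the group itself moves the number by a smaller amount, with the boronic acid of compound 1 giving the higher number. A large downward step is therefore expected in this assay, landing between the numbers of compound 1 and compound 2.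

Compound 4 is expected to give about 40 nM in this assay, within 10 nM to 150 nM. The expected step is an 18-fold lower number from compound 3 to compound 4 (1.26 log units; beyond the scatter).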

Compound 4, half-maximal inhibitory concentration: 750 nM
Estimate against measurement, compound 4: 19-fold (1.27 log units) below, and the stated range ends below it.
By their numbers in this assay, from the lowest: compound 2; then compound 1; then compounds 3 and 4 (each within the scatter of the next).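

In this assay, a 4-substituted aryl does not by itself keep the number low: carbamoyl in place of cyano on an aromatic carbon gives (a 44-fold higher number from compound 2 to compound 4 (1.64 log units; beyond the scatter)), a large step that leaves 4-carbamoylphenyl level with 3-cyanophenyl (a 1.0-fold higher number from compound 3 to compound 4 (0.02 log units; within the scatter)). The group itself therefore matters at least as much as where it sits, and the boronic acid also compares favourably with the carbamoyl (an 8.2-fold higher number from compound 1 to compound 4 (0.92 log units; beyond the scatter)), so that among the three 4-substituted aryls the nitrile of compound 2 gives the lowest number and compound 1 an intermediate one. Nothing available explains why the carbamoyl group gives so much higher a number than the nitrile.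

Still open, on these data alone, is whether any group other than the nitrile can match compound 2 at (17 nM) on this aromatic carbon, for instance a carboxylic acid, a methyl ester or an amine. The ethoxy and bromo groups stay fixed throughout, so whether this ranking of aryl groups would survive with, say, a methoxy group in place of the ethoxy also remains untested in the compounds shown.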